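Phthalimide anilide antagonists: swapping the amide aryl for cyclopropyl

The source may hold more compounds than are shown below. What is called first, only, known or untested is meant among the compounds shown, and "the series" means these compounds.

Compound 1 `COc1ccccc1C(=O)Nc1cccc(NC(=O)C(C)C)c1`: > 30000 nM
Compound 2 `O=C(Nc1cccc(Cl)c1)c1cccc(N2C(=O)c3ccccc3C2=O)c1`: 1780 nM

In an in vitro functional assay on HEK293-A cells for antagonist activity at metabotropic glutamate receptor 5 (Rattus norvegicus), read by calcium flux (on this read-out higher numbers stand for weaker inhibition and lower numbers for stronger inhibition), compound 1 reaches only (the limit of > 30000 nM in this assay, at which 1 of the 2 values shown sits), a limit rather than a number. Compound 2 therefore holds the only number shown, giving 1780 nM in this assay. Compound 3 `O=C(NC1CC1)c1cccc(N2C(=O)c3ccccc3C2=O)c1` differs by cyclopropyl in place of 3-chlorophenyl on an amide-type nitrogen. Among the measured compounds shown here, no measured pair separates at this position, so the direction is untested; the step is expected to weaken inhibition beyond the scatter, a 6.7-fold higher number from compound 2 to compound 3 (0.83 log units; beyond the scatter), as the estimate for compound 3 in this assay is 12000 nM (range 3000 nM to 30000 nM).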

Compound 3, half-maximal inhibitory concentration: > 30000 nM
Compound 3 gave a limit, no number; the forecaster's own chance of this, stated with the estimate: 40%; middle value at least 2.5-fold (0.39 log units) away from the limit.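

In this assay, the step at the amide-type nitrogen is an at least 16-fold higher number from compound 2 to compound 3 (1.22 log units; beyond the scatter), which shows that on the shared core this position does not accept cyclopropyl in place of 3-chlorophenyl without a large loss of inhibition. Compound 3 gives only a limit, not a number, so the full size of the loss cannot be read: the limit of > 30000 nM in this assay, at which 2 of the 3 values shown sit.

As far as these compounds go, what phenyl without the chlorine, or a cyclohexyl, would give on that nitrogen remains open. So does whether the chlorine or the aromatic ring matters more for the inhibition by compound 2.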